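Compound 3 to compound 4: exchanging the imidazole for a thiazole

The source may hold more compounds than are shown below. What is called first, only, known or untested is meant among the compounds shown, and "the series" means these compounds.

Measured in a functional assay (trachea) with Cavia porcellus as the target; a lower number here means a stronger inhibitor, a higher number a weaker inhibitor:
Compound 1 `CCn1nc(-c2cccnc2)c2ccccc2c1=O` gives 1320 nM
Compound 2 `O=c1c2ccccc2c(-c2cccnc2)nn1CC1CCCCC1` gives 209 nM
Compound 3 `CCn1nc(-n2ccnc2)c2ccccc2c1=O` gives 5370 nM

Compound 3 has the highest number of the three. Compound 4 `CCn1nc(-c2nccs2)c2ccccc2c1=O` keeps the ethyl group and carries 1,3-thiazol-2-yl in place of 1H-imidazol-1-yl on an aromatic carbon and nothing else changes. Among the measured compounds shown here, the one measured change at this place is a 4.1-fold higher number from compound 1 to compound 3 (0.61 log units; beyond the scatter), modest and beyond the scatter. The other, a 6.3-fold lower number from compound 1 to compound 2 (0.80 log units; beyond the scatter), concerns the chain and does not bear on this exchange. No thiazole has been measured yet, so the thiazole is expected to recover only part of the gap seen with pyridin-3-yl. The expected change in this assay is a 2.1-fold lower number from compound 3 to compound 4 (0.33 log units; beyond the scatter), a modest move toward a lower number. For compound 4 the estimated value is 2500 nM, with an expected range from 700 nM to 8000 nM.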

Compound 4, half-maximal inhibitory concentration: 3160 nM
Compound 4: the middle estimate sits 1.3-fold (0.10 log units) below what was measured, within the range that was stated.
By their numbers in this assay, from the lowest: compound 2; then compound 1; then compounds 4 and 3 (each within the scatter of the next).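

In this assay, 1,3-thiazol-2-yl in place of 1H-imidazol-1-yl gives a 1.7-fold lower number from compound 3 to compound 4 (0.23 log units; within the scatter), so at this position the two five-membered aromatic rings cannot be told apart. Against pyridin-3-yl, the thiazole shows a 2.4-fold higher number from compound 1 to compound 4 (0.38 log units; beyond the scatter), and with the imidazole this makes two five-membered rings that stand on the weaker side of the six-membered ring of compound 1. Nothing available accounts for this difference.

On these data alone, whether a plain phenyl ring or a furan at this position would match pyridin-3-yl remains open. So does whether the cyclohexylmethyl chain of compound 2 would change the thiazole as it changed the pyridine.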